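Methyl in place of ethyl on the ester

This account rests on a few compounds, and the source may have more. Where it says the series, first, only, none or still open, it means among the compounds named here.

Compound 1 `CCOC(=O)C1=C(C)N(c2ccccc2)C=CC1c1ccccc1`: -37.1%
Compound 2 `CCOC(=O)C1=C(C)N(c2ccc(F)cc2)C=CC1c1ccccc1`: -35.8%
Compound 3 `CCOC(=O)C1=C(C)N(c2ccc(Br)cc2)C=CC1c1ccccc1`: -32.1%

In a functional assay for inhibition, using microsomes, tested at 200 ug/mL (on this read-out higher numbers stand for a weaker effect at the one concentration tested and lower numbers for a stronger effect), compound 1 gives the lowest of the three numbers, yet each neighbour lies within the scatter: a number 1.3 percentage points higher from compound 1 to compound 2 (within the scatter), a number 5 percentage points higher from compound 1 to compound 3 (within the scatter), and likewise a number 3.7 percentage points higher from compound 2 to compound 3 (within the scatter). Compound 4 `COC(=O)C1=C(C)N(c2ccccc2)C=CC1c1ccccc1` differs from compound 1 in one place: hydrogen in place of methyl on a saturated chain carbon bound to an oxygen next to a carbonyl group. All three measured steps alter a substituent on an aromatic carbon and leave the ethoxycarbonyl group untouched, so none of them bears directly on this change; they merely show that small single changes to this core have not moved the read-out beyond the scatter. Compound 4 is therefore expected to sit near compound 1 in this assay, with a number 0.1 percentage points higher from compound 1 to compound 4 (within the scatter) meaning no step beyond the scatter. The estimate for compound 4 is -37%, ranging from -52% to -22%.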

Compound 4, a percentage reported as activity, at one concentration (the size of the read-out at that concentration, not a potency): -37.3%
The estimate for compound 4 lay 0.3 percentage points above the measured number; low and high end bracket the measured number.
By their numbers in this assay, from the lowest: compounds 4, 1, 2 and 3 (each within the scatter of the next).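

The earlier steps shown here all fall on an aromatic carbon, whereas this one alone touches the ester: in this assay, going from ethoxycarbonyl to methoxycarbonyl gives a number 0.2 percentage points lower from compound 1 to compound 4 (within the scatter). At this position, then, the read-out does not separate ethyl from methyl. Nothing available offers an explanation for this result.

The compounds shown leave open whether a longer chain such as butyl on the ester oxygen would also stay within the scatter of compound 1. They also leave open what a carboxylic acid or an amide in place of the ester would do.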